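Aminothiazole series: bromo to hydroxy on the anilino ring

The compounds below may be only part of what the source reports. "The series", "measured", "known", "first", "only" and "open" are said of these compounds alone.

Measured so far in a functional assay on RCC4 cells (Homo sapiens) for inhibition, read by XTT assay, with a stated time of 4 days; a lower number here means a stronger inhibitor, a higher number a weaker inhibitor:
- compound 1, `Brc1cccc(Nc2nc(-c3ccncc3)cs2)c1`: 40700 nM
- compound 2, `Cc1cccc(Nc2nc(-c3ccnc(-c4cnn(C)c4)c3)cs2)c1`: 5200 nM; 5250 nM (2 entries)
- compound 3, `Oc1ccc(Nc2nc(-c3ccncc3)cs2)cc1`: 5370 nM

Compound 1 stands at the highest of the two single numbers in this assay. The nearest is compound 3, whose value is lower by a margin that lies beyond the scatter. Compound 2 does not carry a single number; its repeat entries, (the several entries of compound 2 in this assay, 5200 nM; 5250 nM (2 entries)), sit close together and near compound 3.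

The next compound is compound 4, `Oc1cccc(Nc2nc(-c3ccncc3)cs2)c1`. Against compound 1 the change is hydroxy in place of bromo on an aromatic carbon, on the aromatic carbon that is meta to a large group. Going by the values given here, no direct pair within this set isolates that exchange, so the expectation rests on what the numbers show: compound 1 with bromo at that position gives 40700 nM, while compound 3, carrying hydroxy elsewhere on the same ring, gives 5370 nM.

On that basis the step from bromo to hydroxy is expected to lower the number, a 5.1-fold lower number from compound 1 to compound 4 (0.71 log units; beyond the scatter), beyond the scatter. Compound 4 is therefore estimated at 8000 nM, with a range from 3000 nM to 25000 nM.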

Compound 4, half-maximal inhibitory concentration: 28800 nM
The estimate for compound 4 lay 3.6-fold (0.56 log units) below the measured number; the whole stated range lies below it.
By their numbers in this assay, from the lowest: compound 3; then compounds 4 and 1 (each within the scatter of the next).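

In this assay, hydroxy in place of bromo on the aromatic carbon meta to a large group gives no separation beyond the scatter: a 1.4-fold lower number from compound 1 to compound 4 (0.15 log units; within the scatter). Hydroxy at this position therefore does not reproduce the lower number seen with hydroxy elsewhere on the same ring: compound 4 gives 28800 nM, while compound 3 gives 5370 nM. Nothing among the available observations bears on why this exchange stays within the scatter.

From the compounds shown here alone, it remains open whether an amine, a methoxy group or a carboxylic acid on this same aromatic carbon would separate from bromo and hydroxy. Compound 2 differs from compound 4 in more than one place, so its values give no reading on this position.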